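Swapping the Amide Substituent on Compound 3

A few compounds are considered here, and "the series" means these few. Any claim that something is new, unique, unknown or untested is made for them only; others in the source may bear on it.

The values so far in a physicochemical assay for solubility, read by spectrophotometry, measured as kinetic solubility, at pH 8, tested at 500 uM (on this read-out lower numbers stand for lower solubility and higher numbers for higher solubility), are these
compound 1 `Cn1ccc2ccc(-c3cc(Nc4cnccc4C(=O)NCc4cncnc4)cc4nccnc34)cc21` gives 233 ug/mL
compound 2 `CN1CCC(NC(=O)c2ccncc2Nc2cc(-c3ccc4ccn(C)c4c3)c3nccnc3c2)CC1=O` gives 48 ug/mL
compound 3 `CN1CC(NC(=O)c2ccncc2Nc2cc(-c3ccc4ccn(C)c4c3)c3nccnc3c2)CCC1=O` gives 253 ug/mL

Compound 3 and compound 1 lie within the scatter of each other (a 1.1-fold higher number from compound 1 to compound 3 (0.04 log units; within the scatter)), and together they share the top of the measured range. Compound 2 stands clearly apart from compound 3 (a 5.3-fold higher number from compound 2 to compound 3 (0.72 log units; beyond the scatter)).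

The unmeasured compound 4 `CC(=O)N1CC(NC(=O)c2ccncc2Nc2cc(-c3ccc4ccn(C)c4c3)c3nccnc3c2)C1` carries 1-acetylazetidin-3-yl in place of 1-methyl-6-oxopiperidin-3-yl on an amide-type nitrogen. Three measured steps alter the group at this same place. One stays within the scatter (a 1.1-fold higher number from compound 1 to compound 3 (0.04 log units; within the scatter)), while two are modest and go beyond it (a 4.9-fold lower number from compound 1 to compound 2 (0.69 log units; beyond the scatter) and a 5.3-fold higher number from compound 2 to compound 3 (0.72 log units; beyond the scatter)). The last of these shows that swapping one substituent for a closely related one can still move the number. Among the measured compounds shown here, no measured compound carries 1-acetylazetidin-3-yl, so the data offer no direct guide.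

With compound 3 already at the top of the range, a fall is likelier than a rise. The expected change is small and is estimated as a 1.6-fold lower number from compound 3 to compound 4 (0.20 log units; within the scatter) in this assay (an estimate only). The estimated value for compound 4 is 160 ug/mL with an expected range of 55 ug/mL to 270 ug/mL (not yet a measurement).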

Compound 4, solubility: 244 ug/mL
Compound 4: middle estimate off by 1.5-fold (0.18 log units), on the low side; the range from low to high includes it.
By their numbers in this assay, from the lowest: compound 2; then compounds 1, 4 and 3 (each within the scatter of the next).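

In this assay, the four-membered ring of 1-acetylazetidin-3-yl can stand in for the six-membered ring of 1-methyl-6-oxopiperidin-3-yl on the amide-type nitrogen without moving the reading beyond the scatter (a 1.0-fold lower number from compound 3 to compound 4 (0.02 log units; within the scatter)), so at this position ring size alone does not set the number. The same holds when the new group is set against the (pyrimidin-5-yl)methyl group (a 1.0-fold higher number from compound 1 to compound 4 (0.02 log units; within the scatter)), which means that three quite different groups now share the top of the measured range. Compound 2 stays apart from this new compound too (a 5.1-fold higher number from compound 2 to compound 4 (0.71 log units; beyond the scatter)), so among the four compounds the low reading belongs to 1-methyl-2-oxopiperidin-4-yl alone and not to non-aromatic rings in general.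

No measurement shown explains why that one group stands apart from the others. As far as these compounds go, it also remains open whether a ring with a free amine in place of the carbonyl, a carboxylic acid or a longer open chain on the same nitrogen would stay in this top group or fall towards compound 2.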